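The compounds below may be only part of what the source reports. "The series", "measured", "known", "first", "only" and "open" are said of these compounds alone.

Measured in a functional assay on T98G cells (Homo sapiens) for inhibition, read by colorimetric assay and MTT assay, with a stated time of 72 h; on this read-out higher numbers stand for weaker inhibition and lower numbers for stronger inhibition:
- compound 1 `C=CCCCCOc1ccccc1-c1cnc(OCCC=C)n1C`: 29000 nM
- compound 2 `COc1ccccc1-c1cnc(OC)n1C`: > 100000 nM

Compound 2 has no number of its own, only a limit of the assay: > 100000 nM. This leaves the two compounds with just one true number between them.

Compound 3 `C=CCCCCOc1ccccc1-c1cnc(OC)n1C` differs from compound 2 in one place: pent-4-en-1-yl in place of hydrogen on a saturated chain carbon bound to an oxygen on an aromatic ring. Pent-4-en-1-yl takes the place of hydrogen on a saturated chain carbon bound to an oxygen on an aromatic ring, so a methoxy becomes a (hex-5-en-1-yl)oxy.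

Among the measured compounds shown here, no pair of measured compounds differs in one place only, so no measured step sets the size of this change in this assay. For the measured compounds named here, the only numerical anchor is compound 1, which gives 29000 nM. A modest move towards stronger inhibition is expected, and the reading may well remain at the limit. The estimated change is an at least 1.8-fold lower number from compound 2 to compound 3 (0.25 log units; that floor lies within the scatter). For compound 3 the expected value is 55000 nM, with an estimated range of 25000 nM to 100000 nM.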

Compound 3, half-maximal inhibitory concentration: > 100000 nM
Compound 3 was reported as a limit (the forecaster's own chance of this, stated with the estimate: 30%); middle value at least 1.8-fold (0.25 log units) from the limit.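

In this assay, compound 3 gives only a limit of the assay (> 100000 nM), not a true number. The step between compound 2 and compound 3 cannot be read, because both values are limits: the limit of > 100000 nM in this assay, at which 2 of the 3 values shown sit. The hex-5-en-1-yl chain therefore shows no measurable gain here, but the comparison with compound 1 can still be made: hydrogen in place of allyl on a saturated chain carbon bound to an oxygen on an aromatic ring gives an at least 3.4-fold higher number from compound 1 to compound 3 (0.53 log units; beyond the scatter), so the (hex-5-en-1-yl)oxy group alone does not bring the reading inside the limit, while compound 1, which carries the allyl as well, gives a true number.

From the compounds shown here alone, whether the (hex-5-en-1-yl)oxy group contributes anything in its own right stays open, as does the size of any such contribution, since a reading at the limit hides it. The compounds shown also leave open whether the double bond in these chains matters, which a saturated hexyl chain could test, and how an amine or a carboxylic acid at the end of the chain would read.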